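Replacing carboxy with (dimethylamino)methyl on the shared core

This account rests on a few compounds, and the source may have more. Where it says the series, first, only, none or still open, it means among the compounds named here.

Values in a functional assay on MCF7 cells (Homo sapiens) for antiproliferative activity, read by MTT assay, with a stated time of 48 h; a lower number here means a stronger inhibitor, a higher number a weaker inhibitor:
Compound 1 `CC(C)=CCC[C@]1(C)/C=C/[C@@H](OC(=O)C=C(C)C)[C@](C)(O)/C=C/C(=O)/C(CF)=C\C1`: 240 nM
Compound 2 `CC(=O)OC/C1=C/C[C@](C)(CCC=C(C)C)/C=C/[C@@H](OC(=O)C=C(C)C)[C@](C)(O)/C=C/C1=O`: 4510 nM
Compound 3 `CC(C)=CCC[C@]1(C)/C=C/[C@@H](OC(=O)C=C(C)C)[C@](C)(O)/C=C/C(=O)/C(C(=O)O)=C\C1`: 16100 nM

Compound 3 has the highest number of the three, so it is the weakest inhibitor measured so far in this assay. Compound 1 and compound 2 differ from each other by a 19-fold higher number from compound 1 to compound 2 (1.27 log units; beyond the scatter), and both lie below compound 3.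

Next comes compound 4 `CC(C)=CCC[C@]1(C)/C=C/[C@@H](OC(=O)C=C(C)C)[C@](C)(O)/C=C/C(=O)/C(CN(C)C)=C\C1`, which carries (dimethylamino)methyl in place of carboxy on a double-bonded ring carbon.

For the measured compounds named here, two measured steps bear on this change, and both have carboxy entering. Carboxy replacing fluoromethyl gives a 67-fold higher number from compound 1 to compound 3 (1.83 log units; beyond the scatter), a large step. Carboxy replacing acetoxymethyl gives a 3.6-fold higher number from compound 2 to compound 3 (0.55 log units; beyond the scatter), a modest one. Compound 4 also loses carboxy and has a substituted methyl at that place, so a fall in the number is expected. Going by the values given here, no measured compound carries a dimethylamino group, so the size stays uncertain, and a step between those two sizes seems the fair expectation. The estimated change is an 8.1-fold lower number from compound 3 to compound 4 (0.91 log units; beyond the scatter), a clear move towards stronger inhibition. For compound 4 the expected value is 2000 nM, with an estimated range of 450 nM to 9000 nM.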

Compound 4, half-maximal inhibitory concentration: 690 nM
Compound 4: the middle estimate sits 2.9-fold (0.46 log units) above what was measured; the range from low to high includes it.
By their numbers in this assay, from the lowest: compound 1; then compound 4; then compound 2; then compound 3.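

In this assay the change from carboxy to (dimethylamino)methyl on the double-bonded ring carbon gives a 23-fold lower number from compound 3 to compound 4 (1.37 log units; beyond the scatter) and shows that this place accepts a nitrogen-bearing substituted methyl; all three substituted methyl groups shown now give lower numbers than carboxy, and no compound here goes against that. On the saturated chain carbon bound to that ring carbon, dimethylamino in place of acetoxy gives a 6.5-fold lower number from compound 2 to compound 4 (0.82 log units; beyond the scatter) while dimethylamino in place of fluoro gives a 2.9-fold higher number from compound 1 to compound 4 (0.46 log units; beyond the scatter) and so the new group falls inside the range of the substituents on this carbon, on the stronger side of acetoxy and the weaker side of fluoro. No measurement on hand accounts for this order, which remains a description of the numbers only.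

Still open, on these data alone, is whether a cyclic amine such as morpholin-4-ylmethyl, or a primary aminomethyl, would fall nearer to compound 1 or to compound 4 on the shared core. Also open, as far as these compounds go, is whether a longer chain carrying the same dimethylamino group would keep the drop in number seen against carboxy.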